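The compounds below may be only part of what the source reports. "The series", "measured", "known", "first", "only" and "open" are said of these compounds alone.

Within the series compound 3 `COc1ccc(/C=C2\S/C(=N\c3csc(-c4ccc(Cl)cc4)c3)NC2=O)cc1` gives the only number: in a functional assay on SW-620 cells (Homo sapiens) for cytotoxicity, read by MTT assay, with a stated time of 72 h (a higher number here means a weaker inhibitor, a lower number a stronger inhibitor), compound 3 gives 28100 nM. Compound 1 `Cc1ccc(-c2cc(/N=C3/NC(=O)CS3)cs2)cc1` sits at a limit of the assay, > 50000 nM. Compound 2 `O=C1N/C(=N/c2csc(-c3ccc(Cl)cc3)c2)S/C1=C\c1ccccc1` likewise sits at a limit, > 50000 nM. For the measured compounds named here, the one readable step is an at least 1.7-fold lower number from compound 2 to compound 3 (0.25 log units; that floor lies within the scatter); it rests on the limit of > 50000 nM in this assay, at which 2 of the 3 values shown sit, and so fixes neither size nor direction. Compound 4 `Cc1ccc(/C=C2\S/C(=N\c3csc(-c4ccc(Cl)cc4)c3)NC2=O)cc1` differs from compound 3 by methyl in place of methoxy on an aromatic carbon. Going by the values given here, no measured step swaps methyl for methoxy; the step from compound 2 to compound 3 shows only that hydrogen on that aromatic carbon reached no number. For compound 4 an expected step of a 1.4-fold higher number from compound 3 to compound 4 (0.15 log units; within the scatter) is taken, toward a similar or weaker number. Compound 4 is therefore estimated at 40000 nM, between 15000 nM and 100000 nM.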

Compound 4, half-maximal inhibitory concentration: 1500 nM
Estimate against measurement, compound 4: 27-fold (1.43 log units) above; the measured number lies below the stated range.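

In this assay, for the compounds shown here, the change from 4-methoxyphenyl to 4-methylphenyl gives a 19-fold lower number from compound 3 to compound 4 (1.27 log units; beyond the scatter), so the group at this position can shift the number well beyond the scatter, which the earlier compounds could not show. Methyl in place of hydrogen gives an at least 33-fold lower number from compound 2 to compound 4 (1.52 log units; beyond the scatter); this is only a floor, and its true size stays unknown, since compound 2 sits at a limit: the limit of > 50000 nM in this assay, at which 2 of the 4 values shown sit.

Still open, from the compounds shown here alone, is whether methyl is special here or whether an ethyl chain, a chlorine atom or an amine at the same position would match compound 4 at 1500 nM.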